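The source may report more compounds than this note shows. Statements on the series, on what has been measured and on what is new or still open speak of the compounds shown alone.

The measured compounds and their values in a functional assay on A549 cells (Homo sapiens), read by MTT assay, with a stated time of 72 h; a higher number here means a weaker inhibitor, a lower number a stronger inhibitor:

Compound 1, `C#Cc1cn([C@@H]2O[C@H](CO)[C@@H](O)[C@H]2O)c2ncnc(C)c12`, gives 19200 nM.
Compound 2, `Cc1ncnc2c1c(-c1ccoc1)cn2[C@@H]1O[C@H](CO)[C@@H](O)[C@H]1O`, gives only a limit of the assay, > 20000 nM.
Compound 3, `C#Cc1cn([C@@H]2O[C@H](CO)[C@@H](O)[C@H]2O)c2nc(N)nc(OC)c12`, gives only a limit of the assay, > 100000 nM.

Compound 1 and compound 2 share one core and differ in a single place: furan-3-yl in place of ethynyl on an aromatic carbon. The measured step is an at least 1.0-fold higher number from compound 1 to compound 2 (0.01 log units; that floor lies within the scatter); as compound 2 sits at the limit of > 20000 nM in this assay, at which 1 of the 3 values shown sits, that step can only be given as a floor, not as a finished number. Compound 3 carries a different core, and the difference between the two cores is not broken down here. Compound 3 sits at the limit of > 100000 nM in this assay, at which 1 of the 3 values shown sits, which is a limit and not a number.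

Compound 4, `COc1nc(N)nc2c1c(-c1ccoc1)cn2[C@@H]1O[C@H](CO)[C@@H](O)[C@H]1O`, has not yet been measured in this assay. It differs from compound 3 by the same change that turns compound 1 into compound 2: furan-3-yl in place of ethynyl on an aromatic carbon. The place where the change is made is the same word for word, so this is the same change and not merely the same kind.

The expectation for the step rests on compound 3 already standing at the limit of > 100000 nM in this assay, at which 1 of the 3 values shown sits, and on the earlier step of an at least 1.0-fold higher number from compound 1 to compound 2 (0.01 log units; that floor lies within the scatter), which gave no sign of a lower number. The expected step is a step that the limit leaves unreadable from compound 3 to compound 4. Compound 4 is therefore estimated at about 150000 nM in this assay, most likely reported again only as a limit, with a range from 60000 nM to 600000 nM.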

Compound 4, half-maximal inhibitory concentration: > 20000 nM
Compound 4 was reported as a limit; the forecaster's own chance of this, stated with the estimate: 85%; the middle value is on the limit's open side.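

In this assay compound 3 gives > 100000 nM, which is a limit and not a number. Compound 4 gives > 20000 nM, which is also a limit. No size can be read for the step between compound 3 and compound 4. The compounds shown leave open how much furan-3-yl in place of ethynyl on an aromatic carbon really changes the number on either core.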